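Removing the nitro group from compound 2

The compounds below may be only part of what the source reports. "The series", "measured", "known", "first", "only" and "open" are said of these compounds alone.

Compound 1 `Cn1c(-c2ccccc2F)cnc1NC(=O)c1ccc(F)cc1`: > 100000 nM
Compound 2 `COc1ccc(-c2cnc(NC(=O)c3ccc([N+](=O)[O-])cc3)n2C)cc1`: > 100000 nM
Compound 3 `COc1ccc(-c2cn(C)c(NC(=O)c3ccc(F)cc3)n2)cc1`: > 50000 nM

Of the compounds shown here, three have so far been tested in a toxicity assay on THP-1 cells (Homo sapiens) for inhibition; a lower number here means that less compound is tolerated, a higher number that more compound is tolerated. None of the three gives a number; each value is a limit of the assay. For compound 2 the value > 100000 nM is such a limit. Compound 1 sits at the same limit, (the limit of > 100000 nM in this assay, at which 2 of the 3 values shown sit). Compound 3 sits at a different one, (the limit of > 50000 nM in this assay, at which 1 of the 3 values shown sits). Compound 2 therefore stands nowhere on a scale of numbers: all that is known is that it is tolerated up to the limit, as are the two others.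

Compound 4 `COc1ccc(-c2cnc(NC(=O)c3ccccc3)n2C)cc1` has not yet been measured in this assay. It differs from compound 2 in a single place: hydrogen in place of nitro on an aromatic carbon. Among the compounds with values here, no step between two measured compounds is available to gauge this change, since none of the measured pairs differs in one place. The expected step is a number no higher from compound 2 to compound 4 (the limit leaves the size open), that is, nothing beyond the scatter. Compound 4 is accordingly estimated at 100000 nM, within 40000 nM to 300000 nM, and most likely it will again be reported only as a limit.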

Compound 4, half-maximal cytotoxic concentration: > 100000 nM
Compound 4 gave a limit, no number; the forecaster's own chance of this, stated with the estimate: 80%; the middle value lies on the limit itself.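

Compound 2 and compound 4 both sit at a limit of the assay in this assay, so no step between them can be read: the limit of > 100000 nM in this assay, at which 3 of the 4 values shown sit.

The compounds shown leave open whether any of them has a half-maximal cytotoxic concentration that can be given as a number, and what hydrogen in place of nitro changes.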